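Cyclopropyl for bromo on the core of compound 2

A few compounds are considered here, and "the series" means these few. Any claim that something is new, unique, unknown or untested is made for them only; others in the source may bear on it.

Compound 2 `O=C(Nc1cccc(F)c1)c1cc(=O)[nH]c2cc(Br)ccc12`: 7300 nM
Compound 3 `O=C(Nc1cc(F)cc(F)c1)c1cc(=O)[nH]c2cc(Br)ccc12`: 11200 nM
Compound 1 `O=C(Nc1ccc(Cl)cc1)c1cc(=O)[nH]c2cc(Br)ccc12`: a limit, > 20000 nM

In a functional assay on KYSE-410 cells (Homo sapiens) for antiproliferative activity, read by MTT assay, with a stated time of 72 h (a higher number here means a weaker inhibitor, a lower number a stronger inhibitor), compound 2 gives 7300 nM, the lowest of the two numbers shown, and compound 3 gives 11200 nM; the step of a 1.5-fold higher number from compound 2 to compound 3 (0.19 log units; within the scatter) stays within the scatter. Compound 1 reports only a limit in this assay, > 20000 nM, as the limit of > 20000 nM in this assay, at which 1 of the 3 values shown sits, shows. The step of an at least 2.7-fold lower number from compound 1 to compound 2 (0.43 log units; beyond the scatter) is the only one beyond the scatter, and both measured steps alter the aryl group on the amide-type nitrogen; none touches the bromo on the core. Compound 4 `O=C(Nc1cccc(F)c1)c1cc(=O)[nH]c2cc(C3CC3)ccc12` differs from compound 2 by cyclopropyl in place of bromo on an aromatic carbon. Within the data shown here, no measured step bears on this change, so no step beyond the scatter is expected in either direction in this assay. Compound 4 is therefore estimated at 7300 nM, between 2500 nM and 22000 nM, the expected step being no change at the digits printed from compound 2 to compound 4 (within the scatter).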

Compound 4, half-maximal inhibitory concentration: > 20000 nM
Compound 4 gave a limit, no number; the forecaster's own chance of this, stated with the estimate: 15%; at least 2.7-fold (0.43 log units) between middle value and limit.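

Among these compounds, the bromo on the core is the first place seen to matter: in this assay, cyclopropyl in place of bromo gives an at least 2.7-fold higher number from compound 2 to compound 4 (0.43 log units; beyond the scatter). The aryl group on the amide-type nitrogen stays the same in this step, so a change on the core alone can move the read-out beyond the scatter. Compound 4 reports only a limit, the same one as compound 1: the limit of > 20000 nM in this assay, at which 2 of the 4 values shown sit.

Only bromo and cyclopropyl are shown on this carbon, leaving open whether the change in the read-out is specific to cyclopropyl or follows any replacement of bromo. A chloro group or an amine on the same carbon would bear on this question.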